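Chloro in place of methyl on the shared core

The source may report more compounds than this note shows. Statements on the series, on what has been measured and on what is new or still open speak of the compounds shown alone.

Measured in an ADME assay on CHO cells (Cricetulus griseus) for inhibition, read by MTT assay; a higher number here means a weaker inhibitor, a lower number a stronger inhibitor
- compound 1 `CC(C)(C)NCc1cc(C(C)(C)C)cc(Nc2nc3cc(F)c(F)cc3[nH]2)c1O` gives 34200 nM
- compound 2 `Cc1cc(CNC(C)(C)C)c(O)c(Nc2nc3cc(F)c(F)cc3[nH]2)c1` gives 16700 nM

Of the two measured compounds, compound 2 has the lower number in this assay (16700 nM), which marks it as the stronger inhibitor of the pair. The next compound to be read is compound 3 `CC(C)(C)NCc1cc(Cl)cc(Nc2nc3cc(F)c(F)cc3[nH]2)c1O`, and the change from compound 2 is chloro in place of methyl on an aromatic carbon on the aromatic carbon para to a hydroxy group.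

Within the data shown here, only one measured step bears on this carbon. It is a 2.0-fold lower number from compound 1 to compound 2 (0.31 log units; beyond the scatter) and it is modest, with methyl in place of tert-butyl. Among the measured compounds shown here, no chloro compound has been measured yet, so that single step gives only a rough scale and no firm direction for the new change. A small step at most is therefore expected. The expected step is a 1.1-fold higher number from compound 2 to compound 3 (0.03 log units; within the scatter) and nothing beyond the scatter is anticipated. The estimated value for compound 3 is 18000 nM (expected range 8000 nM to 40000 nM).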

Compound 3, half-maximal inhibitory concentration: 39700 nM
Compound 3: middle estimate off by 2.2-fold (0.34 log units), on the low side; the range from low to high includes it.
By their numbers in this assay, from the lowest: compound 2; then compounds 1 and 3 (each within the scatter of the next).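

In this assay the carbon para to a hydroxy group now separates methyl from chloro, with a 2.4-fold higher number from compound 2 to compound 3 (0.38 log units; beyond the scatter) as the step, so chloro is not a neutral replacement for methyl here and compound 2 remains the strongest inhibitor of the three. Chloro and tert-butyl cannot be told apart at this carbon, with a 1.2-fold higher number from compound 1 to compound 3 (0.06 log units; within the scatter) as the step, so among these three compounds only methyl stands apart, and none of them goes against that reading. Nothing on hand accounts for the gap between methyl and chloro at this carbon.

From the compounds shown here alone, whether the lower number belongs to methyl alone remains open, as ethyl, methoxy, fluoro or an amine on this carbon would be needed to show whether other groups read like methyl or like chloro and tert-butyl. Going by these compounds, all three compounds also carry the ((tert-butyl)amino)methyl group, so it is unknown whether methyl stays apart from chloro and tert-butyl when a different amine, such as a morpholine or a dimethylamine, takes its place.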